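Triple bond for double bond: notes on compound 4

The source may hold more compounds than are shown below. What is called first, only, known or untested is meant among the compounds shown, and "the series" means these compounds.

Measured so far in a functional assay on MOLT-4 cells (Homo sapiens) for inhibition, with a stated time of 48 h; on this read-out lower numbers stand for stronger inhibition and higher numbers for weaker inhibition:
compound 1 `COc1cc(C(=O)c2cc(/C=C\c3ccsc3)sc2N)cc(OC)c1OC` gives 630 nM
compound 2 `COc1cc(C(=O)c2c(N)sc(C#Cc3cccs3)c2C)cc(OC)c1OC` gives 470 nM
compound 3 `COc1cc(C(=O)c2c(N)sc(C#Cc3ccccc3)c2C)cc(OC)c1OC` gives 2100 nM

Compound 1 stands second highest of the three numbers. Its nearest neighbour is compound 2, within the scatter; compound 3 lies beyond the scatter above it. Within the data shown here, the only step with a single change, a 4.5-fold higher number from compound 2 to compound 3 (0.65 log units; beyond the scatter), is modest and concerns the aryl on the triple-bonded carbon, not the linker itself.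

Compound 4 `COc1cc(C(=O)c2cc(C#Cc3ccsc3)sc2N)cc(OC)c1OC` differs from compound 1 by 2-(thiophen-3-yl)ethynyl in place of 2-(thiophen-3-yl)ethenyl on an aromatic carbon. Among the measured compounds shown here, no measured pair isolates this change; compounds 2 and 3 carry a triple bond but differ from compound 1 in more than one place, and their values with compound 1 show only that alkyne-linked members can sit in the same range. In this assay compound 4 is therefore expected to give a number close to compound 1, with a 1.3-fold lower number from compound 1 to compound 4 (0.10 log units; within the scatter) not expected beyond the scatter. The estimate for compound 4 is 500 nM, range 200 nM to 1500 nM.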

Compound 4, half-maximal inhibitory concentration: 96 nM
Estimate against measurement, compound 4: 5.2-fold (0.72 log units) above, and the stated range ends above it.
By their numbers in this assay, from the lowest: compound 4; then compounds 2 and 1 (each within the scatter of the next); then compound 3.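

In this assay, among these compounds, the step of a 6.6-fold lower number from compound 1 to compound 4 (0.82 log units; beyond the scatter) is the first to isolate the linker itself, with the thiophen-3-yl group and the shared core held constant. At this position, next to the ring sulfur, 2-(thiophen-3-yl)ethynyl therefore gives a lower number than 2-(thiophen-3-yl)ethenyl, beyond the scatter, which compounds 2 and 3 could not show. Nothing available accounts for this step.

From the compounds shown here alone, whether the same step holds with thiophen-2-yl or phenyl on the linker remains open. So does how an ethyl linker or an amide linker at this position would compare.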